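A few compounds are considered here, and "the series" means these few. Any claim that something is new, unique, unknown or untested is made for them only; others in the source may bear on it.

Measured compounds:
Compound 1 `COc1ccc(C2CC(c3ccc(NC(=O)c4cc(Cl)ccc4OC)cc3)=NN2c2ccccc2)cc1`: 98%
Compound 2 `COc1ccc(Cl)cc1C(=O)Nc1ccc(C2=NN(c3ccccc3)C(c3ccccc3[N+](=O)[O-])C2)cc1`: 88.4%

In a functional assay on the whole organism (strain albino) with Rattus norvegicus as the target, read by paw edema, with stated times of 1 h and 4 h, at a dose of 50 mg/kg by the oral route (a lower number here means a weaker effect, a higher number a stronger effect of the compound at the dose given), compound 1 gives 98%. Compound 2 stands beside it: in this assay compound 2 gives 88.4%, and the step of a number 9.6 percentage points lower from compound 1 to compound 2 (within the scatter) lies within the scatter, so the two numbers cannot be told apart. Compound 3 `COc1ccc(Cl)cc1C(=O)Nc1ccc(C2=NN(c3ccccc3)C(c3ccc([N+](=O)[O-])cc3)C2)cc1` has not yet been measured. It differs from compound 2 by 4-nitrophenyl in place of 2-nitrophenyl on a saturated ring carbon. Among the compounds with values here, the only measured step that bears on this change is a number 9.6 percentage points lower from compound 1 to compound 2 (within the scatter), which also swaps the group on that same saturated ring carbon and amounts to no more than the scatter. Within the data shown here, no measured pair sets 2-nitrophenyl against 4-nitrophenyl, so the numbers give no direction for this swap. On the strength of a number 9.6 percentage points lower from compound 1 to compound 2 (within the scatter) the expected step is a number 1.6 percentage points higher from compound 2 to compound 3 (within the scatter), nothing beyond the scatter. Compound 3 is therefore estimated at 90%, with a range from 78% to 100%.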

Compound 3, a percentage reported as activity, at one dose (the size of the read-out at that dose, not a potency): 94.1%
Compound 3: middle estimate off by 4.1 percentage points, on the low side, within the range that was stated.
By their numbers in this assay, from the lowest: compounds 2, 3 and 1 (each within the scatter of the next).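

In this assay, within the data shown here, the first direct comparison of the two nitro isomers on the saturated ring carbon, 4-nitrophenyl in place of 2-nitrophenyl, gives a number 5.7 percentage points higher from compound 2 to compound 3 (within the scatter), so the place of the nitro group on this phenyl ring makes no difference that can be read. Nitro in place of methoxy on an aromatic carbon gives a number 3.9 percentage points lower from compound 1 to compound 3 (within the scatter), so all three groups tried at this ring carbon give numbers that cannot be told apart in this assay. Nothing available offers an explanation for these numbers.

On these data alone, it remains open whether a carboxylic acid or an amine in place of the nitro group, or a plain phenyl with nothing on it, would hold the read-out at this level. Only one dose is shown, so whether compound 1, compound 2 and compound 3 would differ in the size of their effect at any other dose also remains open.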